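The compounds below may be only part of what the source reports. "The series", "measured", "known", "first", "only" and "open" are said of these compounds alone.

Working notes on the series. For the measured compounds named here, in a functional assay on MIA PaCa-2 cells (Homo sapiens) for cytotoxicity, read by MTT assay, with a stated time of 72 h (a lower number here means a stronger inhibitor, a higher number a weaker inhibitor), compound 1 `COC1=CC(=O)c2c(COc3ccccc3)c(C)n(C)c2C1=O` gives 409 nM and compound 2 `COC1=CC(=O)c2c(COc3ccc(F)cc3F)c(C)n(C)c2C1=O` gives 75 nM as the lower of the two numbers so far. Compound 3 `COC1=CC(=O)c2c(COc3ccncc3)c(C)n(C)c2C1=O` is not yet measured and differs from compound 2 on an oxygen on a saturated carbon (pyridin-4-yl in place of 2,4-difluorophenyl on an oxygen on a saturated carbon), with pyridin-4-yl in place of 2,4-difluorophenyl. Going by the values given here, only one measured step bears on this place: a 5.5-fold lower number from compound 1 to compound 2 (0.74 log units; beyond the scatter) lies beyond the scatter and comes with 2,4-difluorophenyl in place of phenyl. Among the compounds with values here, compound 3 gives up that 2,4-difluorophenyl, and no measured compound carries pyridin-4-yl, so the guide is rough. A move to a higher number in this assay is expected, probably smaller than that measured step. The estimated step is a 2.3-fold higher number from compound 2 to compound 3 (0.36 log units; beyond the scatter) and remains an expectation only. The expected value for compound 3 is 170 nM (range 45 nM to 600 nM).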

Compound 3, half-maximal inhibitory concentration: 3270 nM
Beside the measured number, compound 3's estimate is 19-fold (1.28 log units) below it; the whole stated range lies below it.
By their numbers in this assay, from the lowest: compound 2; then compound 1; then compound 3.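

In this assay, the place on an oxygen on a saturated carbon proves far more sensitive than the first pair showed: pyridin-4-yl in place of 2,4-difluorophenyl gives a 44-fold higher number from compound 2 to compound 3 (1.64 log units; beyond the scatter), a larger move than the earlier 5.5-fold lower number from compound 1 to compound 2 (0.74 log units; beyond the scatter) in the opposite direction. The change is not just a loss of the fluorine gain, as pyridin-4-yl in place of plain phenyl still gives an 8.0-fold higher number from compound 1 to compound 3 (0.90 log units; beyond the scatter), so the two aromatic rings without fluorine are not interchangeable here. No measurement shown accounts for the size of these steps.

As far as these compounds go, whether the higher number follows the ring nitrogen at this particular ring position remains open, and pyridin-3-yl would test that. Equally open, from the compounds shown here alone, is whether a single fluorine, as in 4-fluorophenyl, carries the gain seen with 2,4-difluorophenyl.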